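Same sulfur swap on two cores: one measured, one expected

The source may hold more compounds than are shown below. What is called first, only, known or untested is meant among the compounds shown, and "the series" means these compounds.

Measured compounds in a functional assay on DU-145 cells (Homo sapiens) for inhibition, read by trypan blue exclusion, with a stated time of 96 h; a higher number here means a weaker inhibitor of growth, a lower number a stronger inhibitor of growth:
compound 1 `COc1ccccc1/C=C(/SCc1ccc(F)cc1)C(=O)c1ccc(Br)cc1` gives 10000 nM
compound 2 `CCOc1ccc(/C=C(/SCc2ccc(F)cc2)C(=O)c2ccc(Br)cc2)cc1OC` gives 50000 nM
compound 3 `COc1ccccc1/C=C(/Sc1ccc(C)cc1)C(=O)c1ccc(Br)cc1` gives 9000 nM

Compound 1 and compound 3 share a core and differ only at the sulfur: 4-methylphenyl in place of 4-fluorobenzyl on a sulfur. This change gave a 1.1-fold lower number from compound 1 to compound 3 (0.05 log units; within the scatter), so the two numbers cannot be told apart. Compound 2 carries a different core; the difference between the two cores is not broken down here, but compound 2 stands well apart from both compound 1 and compound 3, its number being the highest of the three by a margin beyond the scatter.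

Compound 4 `CCOc1ccc(/C=C(/Sc2ccc(C)cc2)C(=O)c2ccc(Br)cc2)cc1OC` is not yet measured. It arises from compound 2 by the same change: 4-methylphenyl in place of 4-fluorobenzyl on a sulfur, at a place described in the same words as in compound 1. Among the measured compounds shown here, since the one measured example of this change, from compound 1 to compound 3, moved the number by only a 1.1-fold lower number from compound 1 to compound 3 (0.05 log units; within the scatter), the step from compound 2 to compound 4 in this assay is expected to be small as well, estimated at a 1.1-fold lower number from compound 2 to compound 4 (0.05 log units; within the scatter). On that basis compound 4 is expected to give about 45000 nM, with a plausible range from 15000 nM to 150000 nM.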

Compound 4, concentration for 50% growth inhibition: 50000 nM
Compound 4: middle estimate off by 1.1-fold (0.05 log units), on the low side; the range from low to high includes it.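

In this assay, putting 4-methylphenyl in place of 4-fluorobenzyl on the sulfur of the core of compound 2 gave no change at the digits printed from compound 2 to compound 4 (within the scatter). Set beside the earlier step on the other core, the swap behaves alike on both, and the two steps cannot be told apart: the same change on two cores in this assay, a 1.1-fold lower number (0.05 log units; within the scatter) from compound 1 to compound 3 and no change at the digits printed (within the scatter) from compound 2 to compound 4, 1.1-fold (0.05 log units) apart, within the scatter of two such steps. This shows that, for these two pairs, the change carried from one core to the other without a detectable difference, but two pairs in one assay do not establish a rule for the series, and they give no reason for the result.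

As far as these compounds go, it remains open whether the swap would stay this small on a core bearing an amine or a carboxylic acid, or in a read-out other than this assay. Also open, from the compounds shown here alone, is how the number would respond on either core if a longer chain, rather than 4-fluorobenzyl or 4-methylphenyl, stood on the sulfur.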